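This account rests on a few compounds, and the source may have more. Where it says the series, first, only, none or still open, it means among the compounds named here.

Measured in an ADME assay on Caco-2 cells (Homo sapiens) for permeability, in the apical to basolateral direction, at pH 7.4; on this read-out higher numbers stand for higher permeability and lower numbers for lower permeability:
Compound 1 `Cc1ccc2[nH]c(C(=O)N[C@H]3CN(S(=O)(=O)c4ccccc4)C[C@@H]3C(=O)NC[C@H]3CCCN3)cc2c1`: 0.11 10^-6 cm/s
Compound 2 `Cc1ccc2[nH]c(C(=O)N[C@H]3CN(S(=O)(=O)c4ccccc4)C[C@@H]3C(=O)NC[C@@H]3CCCN3C)cc2c1`: 0.24 10^-6 cm/s

Of these two, compound 2 stands higher in this assay, at 0.24 10^-6 cm/s. The next compound, compound 3 `Cc1ccc2[nH]c(C(=O)N[C@H]3CN(S(=O)(=O)c4ccccc4)C[C@@H]3C(=O)NC[C@H]3CCCN3C)cc2c1`, has not yet been measured. It is related to compound 2 as follows: the two compounds have the same atoms and bonds and differ only in configuration as drawn: 1 of 3 stereo elements differ; a stereocentre at a saturated ring carbon is drawn S in compound 2 and R in compound 3. Going by the values given here, the only measured step is a 2.2-fold higher number from compound 1 to compound 2 (0.34 log units; beyond the scatter), which is modest and comes with 1-methylpyrrolidin-2-yl in place of pyrrolidin-2-yl. Among the compounds with values here, no measured step changes configuration alone, so the data give no direct guide to the size of this change. Within the data shown here, with only that modest step to go on, no shift beyond the scatter is expected in this assay. The expected step is a 1.2-fold lower number from compound 2 to compound 3 (0.08 log units; within the scatter). Compound 3 is estimated at 0.2 10^-6 cm/s, with an expected range of 0.08 10^-6 cm/s to 0.5 10^-6 cm/s.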

Compound 3, apparent permeability in the Caco-2 assay: 0.08 10^-6 cm/s
Compound 3: the middle estimate sits 2.5-fold (0.40 log units) above what was measured; the range from low to high includes it.
By their numbers in the Caco-2 assay, from the lowest: compounds 3 and 1 (each within the scatter of the next); then compound 2.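

In the Caco-2 assay, compound 2 gives 0.24 10^-6 cm/s and compound 3 gives 0.08 10^-6 cm/s, so configuration at this saturated ring carbon matters on its own, with a 3.0-fold lower number from compound 2 to compound 3 (0.48 log units; beyond the scatter), and the comparison isolates that change: the fact that compounds 2 and 3 differ only in the configuration as drawn. Going by these compounds alone, in a physicochemical assay for lipophilicity, measured as octanol-water partition, at pH 7.4 (a lower number here means a more polar compound, a higher number a more lipophilic compound), compound 2 gives 2.3 and compound 3 gives 2.3, and the same pair shows no change at the digits printed from compound 2 to compound 3 (within the scatter), so the gap in the Caco-2 assay has no counterpart in this one. Back in the Caco-2 assay, methyl on the ring amine nitrogen gives a 1.4-fold lower number from compound 1 to compound 3 (0.14 log units; within the scatter), unlike the earlier 2.2-fold higher number from compound 1 to compound 2 (0.34 log units; beyond the scatter), so the earlier step does not carry over to compound 3.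

The compounds shown leave open whether an ethyl group on that ring nitrogen, or a piperidine in place of the pyrrolidine, would keep this dependence on configuration. They also leave open how changing the configuration at the other stereocentres would register in the Caco-2 assay.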